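The compounds below may be only part of what the source reports. "The series", "measured", "known", "first", "only" and "open" are said of these compounds alone.

Measured so far:
compound 1, `Cc1ccccc1S(=O)(=O)c1ccc(CNC(=O)c2cc3cnccc3[nH]2)cc1`: 13 nM
compound 2, `O=C(NCc1ccc(S(=O)(=O)c2ccccc2)cc1)c1nc2ccncc2s1`: > 10000 nM

In a functional assay on A2780 cells (Homo sapiens) for inhibition, read by sulforhodamine B assay, with a stated time of 72 h (a lower number here means a stronger inhibitor, a higher number a weaker inhibitor), compound 1 gives 13 nM. Compound 2 in this assay gives only a limit of the assay, > 10000 nM, so no number stands for it; this is the limit of > 10000 nM in this assay, at which 1 of the 2 values shown sits. Going by the values given here, compound 2 thus stands at the weak edge of what has been seen, with no measured step joining it to compound 1; the two values show only that compound 1 lies well inside the measurable range and compound 2 outside it.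

Compound 3, `O=C(NCc1ccc(S(=O)(=O)c2ccccc2)cc1)c1cnc2nccn2c1`, is not yet measured. It differs from compound 2 in one place: a group of 9 heavy atoms (6 carbon, 3 nitrogen; one five-membered aromatic ring with 2 hetero atoms, one six-membered aromatic ring with 2 hetero atoms) in place of a group of 9 heavy atoms (6 carbon, 2 nitrogen, 1 sulfur; one five-membered aromatic ring with 2 hetero atoms, one six-membered aromatic ring with 1 hetero atom), on a carbonyl carbon. Among the compounds with values here, no step between measured compounds tells how such an exchange on the carbonyl carbon moves this assay. The expected step is none beyond the scatter, leaving compound 3 near the limit, a number no higher from compound 2 to compound 3 (the limit leaves the size open). Compound 3 is estimated at 10000 nM, range 2000 nM to 50000 nM, with a fair chance that only a limit is reported again.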

Compound 3, half-maximal inhibitory concentration: 68 nM
Estimate against measurement, compound 3: 150-fold (2.17 log units) above, and the stated range ends above it.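

In this assay, going by these compounds alone, the exchange on the carbonyl carbon gives an at least 140-fold lower number from compound 2 to compound 3 (2.16 log units; beyond the scatter), the first reading of how strongly this position responds to a change of group. Compound 2 sits at a limit, so the step fixes only a bound on the size of the change: the limit of > 10000 nM in this assay, at which 1 of the 3 values shown sits. The two groups have the same count of heavy atoms, hydrogen-bond donors and acceptors and carry no net charge, so those counts do not separate them; they differ in sulfur against a third nitrogen and in the hetero atoms of the six-membered ring.

Which of these differences carries the step remains open. Also open, from the compounds shown here alone, is whether a group bearing an amine or a carboxylic acid on the same carbonyl carbon would keep a measurable value.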